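Working notes: solubility across the shared core, compound 3 to compound 4

The compounds below may be only part of what the source reports. "The series", "measured", "known", "first", "only" and "open" are said of these compounds alone.

Of the compounds shown here, three of the shared core have been measured in a physicochemical assay for solubility, read by spectrophotometry, in phosphate buffer, with a stated time of 18 h, at pH 7.4; a higher number here means a more soluble compound, a lower number a less soluble compound. Compound 1 `CCc1ccc(-c2nc3c(c(C)nn3-c3ccccc3)c(-c3ccccc3Br)c2C#N)cc1` gives 1500 nM. Compound 2 `CCc1ccc(-c2nc3c(c(C)nn3-c3ccccc3)c(-c3ccccc3)c2C#N)cc1` gives 47000 nM. Compound 3 `CCCc1ccc(-c2nc3c(c(C)nn3-c3ccccc3)c(-c3ccccc3O)c2C#N)cc1` gives 6500 nM. Going by the values given here, the one single-point step measured so far is a 31-fold higher number from compound 1 to compound 2 (1.50 log units; beyond the scatter), a change on the 2-bromophenyl arm of the core. Compound 3 stands second highest of the three values in this assay: its value lies above that of compound 1 and below that of compound 2, and both gaps exceed the usual scatter.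

Compound 4 `Cc1nn(-c2ccccc2)c2nc(-c3ccc4c(c3)CCCC4)c(C#N)c(-c3ccccc3O)c12` differs from compound 3 only by 1,2,3,4-tetrahydronaphthalen-6-yl in place of 4-propylphenyl on an aromatic carbon. Among the compounds with values here, the measured step from compound 1 to compound 2 concerns a different arm of the core and a different kind of change, so it does not bear directly on this one; no measured pair shows the effect of changing the 4-propylphenyl group itself. Within the data shown here, with no matching precedent, the expectation is a small step, within or close to the scatter, with a slight lean downward. For compound 4 the estimated value in this assay is 4000 nM, within an expected range of 1500 nM to 11000 nM. The expected step is a 1.6-fold lower number from compound 3 to compound 4 (0.21 log units; within the scatter).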

Compound 4, solubility: 13000 nM
The estimate for compound 4 lay 3.3-fold (0.51 log units) below the measured number, and the stated range ends below it.
By their numbers in this assay, from the lowest: compound 1; then compounds 3 and 4 (each within the scatter of the next); then compound 2.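

In this assay, the aromatic carbon next to the ring nitrogen and ortho to a cyano group now has its first measured single-point change: 1,2,3,4-tetrahydronaphthalen-6-yl in place of 4-propylphenyl gives a 2.0-fold higher number from compound 3 to compound 4 (0.30 log units; within the scatter), so the two compounds cannot be told apart in this assay. The comparison holds with the 2-hydroxyphenyl group kept fixed on the other arm of the shared core, and it involves two all-carbon groups of 9 and 10 heavy atoms, each with 0 hydrogen-bond donors and 0 hydrogen-bond acceptors, one with an open propyl chain and the other with a six-membered non-aromatic ring. No supporting measurement is available to explain the values of this pair.

This single pair leaves open how the same position responds to a group of a different kind, such as a 4-aminophenyl group, a 4-carboxyphenyl group or a chain longer than propyl on the phenyl ring. It also leaves open whether the same replacement reads alike when the 2-bromophenyl or unsubstituted phenyl group stands in place of 2-hydroxyphenyl.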